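A Second Acetyl on an Already Capped Nitrogen

A few compounds are considered here, and "the series" means these few. Any claim that something is new, unique, unknown or untested is made for them only; others in the source may bear on it.

Compound 1 `COc1ccc(-c2c(-c3cc(OC)c(OC)c(OC)c3)noc2N)cc1`: 3030 nM
Compound 2 `COc1ccc(-c2c(-c3cc(OC)c(OC)c(OC)c3)noc2NC(C)=O)cc1`: > 50000 nM
Compound 3 `COc1cc(-c2noc(NC(C)=O)c2-c2ccc(Cl)cc2)cc(OC)c1OC`: 1910 nM

In a functional assay on PC-3 cells (Homo sapiens) for cytotoxicity, read by MTT assay, with a stated time of 48 h (on this read-out lower numbers stand for stronger inhibition and higher numbers for weaker inhibition), compound 2 gives > 50000 nM, which is a limit and not a number (the limit of > 50000 nM in this assay, at which 1 of the 3 values shown sits).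

Compound 4 `COc1ccc(-c2c(-c3cc(OC)c(OC)c(OC)c3)noc2N(C(C)=O)C(C)=O)cc1` differs from compound 2 at one place: acetyl in place of hydrogen on an amide-type nitrogen. This is acetyl in place of hydrogen on an amide-type nitrogen, so acetamido becomes diacetylamino. The closest measured change is also acetyl in place of hydrogen on a nitrogen, and it was large, towards weaker inhibition: an at least 16-fold higher number from compound 1 to compound 2 (1.21 log units; beyond the scatter). The other measured step, an at least 26-fold lower number from compound 2 to compound 3 (1.41 log units; beyond the scatter), is also large, but it is chloro in place of methoxy on an aromatic carbon, a different change, so it bears little on this question. A second acetyl might push in the same direction as the first. However, compound 2 offers only a limit as a starting point, so no step beyond the scatter is expected in this assay, and another limit reading is quite likely. The estimated change is a number no higher from compound 2 to compound 4 (the limit leaves the size open). For compound 4 the estimated value is 50000 nM, with an expected range from 12000 nM to 150000 nM.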

Compound 4, half-maximal inhibitory concentration: 360 nM
Compound 4: the middle estimate sits 140-fold (2.14 log units) above what was measured, and the stated range ends above it.
By their numbers in this assay, from the lowest: compound 4; then compounds 3 and 1 (each within the scatter of the next). At a limit, above all of these: compound 2.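

Compound 2 reads > 50000 nM in this assay, and that is a limit of the assay, not a number. Even so, acetyl in place of hydrogen on this amide-type nitrogen gives an at least 130-fold lower number from compound 2 to compound 4 (2.14 log units; beyond the scatter), so a second acetyl does not extend the loss seen with the first but reverses it. The diacetylamino group also outdoes the plain amino group, with an 8.4-fold lower number from compound 1 to compound 4 (0.93 log units; beyond the scatter), so along amino, acetamido and diacetylamino the numbers rise and then fall instead of moving one way.

From the compounds shown here alone, it remains open whether this gain is specific to two acetyl groups or would also appear with other groups on this nitrogen, such as two propionyl groups or a methanesulfonyl group. Going by these compounds, it is also open whether diacetylamino would act the same way with chloro in place of methoxy on an aromatic carbon, as in compound 3.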